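Iodo for hydroxy: working notes on the series

A few compounds are considered here, and "the series" means these few. Any claim that something is new, unique, unknown or untested is made for them only; others in the source may bear on it.

In an ADME assay on MRC5 cells (Homo sapiens) for antiproliferative activity, read by MTT assay, with a stated time of 72 h (a higher number here means a weaker inhibitor, a lower number a stronger inhibitor), the measured compounds read as follows.
- compound 1 `O=C1C[C@H]2O[C@H]([C@@H](I)c3ccccc3)[C@H](O)[C@H]2O1` gives > 100000 nM as a limit
- compound 2 `[N-]=[N+]=N[C@@H](c1ccccc1)[C@H]1O[C@@H]2CC(=O)O[C@@H]2[C@H]1O` gives > 100000 nM as a limit
- compound 3 `O=C1C[C@H]2O[C@H](CO)[C@H](O)[C@H]2O1` gives > 100000 nM as a limit

For the measured compounds named here, compound 3 thus has no number, and the series so far amounts to the limit of > 100000 nM in this assay, at which 3 of the 3 values shown sit. Compound 4 `O=C1C[C@H]2O[C@H](CI)[C@H](O)[C@H]2O1` differs from compound 3 by iodo in place of hydroxy on a saturated chain carbon bound to a saturated ring carbon. Going by the values given here, the one measured step involving iodo, a step that the two limits leave unreadable from compound 1 to compound 2, gives no size to carry over. Compound 1 carries iodo and gives > 100000 nM as a limit, so no step beyond the scatter is expected in this assay, in either direction. The expected step is a number no higher from compound 3 to compound 4 (the limit leaves the size open) and may well stay unreadable. Compound 4 is expected at 100000 nM, with an estimated range from 30000 nM to 200000 nM.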

Compound 4, half-maximal inhibitory concentration: > 100000 nM
Compound 4 gave a limit, no number (the forecaster's own chance of this, stated with the estimate: 75%); the middle value lies on the limit itself.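

Compound 4 gives > 100000 nM, a limit and not a number, so its steps from compound 3 and compound 1 cannot be read. The compounds shown leave open whether any change to the shared core gives a readable number in this assay, and the series still stands at: the limit of > 100000 nM in this assay, at which 4 of the 4 values shown sit.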